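The compounds below may be only part of what the source reports. "The series", "measured", "known", "first", "only" and "open" are said of these compounds alone.

Notes on the series, in an ADME assay on microsomes (Homo sapiens) for metabolic stability; on this read-out higher numbers stand for a longer-lived compound and lower numbers for a shorter-lived compound: compound 2 `CCC(=O)N1CCC(C(=O)N2N=CCC2c2ccccc2)CC1` stands at > 2.75 h, which is a limit of the assay and not a number. Its exact position is therefore unknown. Compound 1 `O=C(c1ccccc1)N1CCC(C(=O)N2N=CCC2c2ccccc2)CC1` gives 1.72 h in this assay.

The next change leads to compound 3 `O=C(C1CCN(C(=O)C(F)(F)F)CC1)N1N=CCC1c1ccccc1`, which has trifluoromethyl in place of ethyl on a carbonyl carbon. Going by the values given here, the same carbonyl carbon changes in the only measured step, with ethyl in place of phenyl: an at least 1.5-fold higher number from compound 1 to compound 2 (0.20 log units; that floor lies within the scatter). That step is a floor within the scatter, and it sets no firm size for a change at this carbon. The evidence available is the limit of > 2.75 h in this assay, at which 1 of the 2 values shown sits. Among the compounds with values here, no measured compound other than compound 3 carries trifluoromethyl, so the direction of the change is not established by the data.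

No shift beyond the scatter is therefore expected in this assay, and the estimated step is an at least 1.1-fold lower number from compound 2 to compound 3 (0.07 log units; that floor lies within the scatter). A reading at the assay limit remains possible. For compound 3 the expected half-life is 2.3 h, with an estimated range from 1.1 h to 3.8 h.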

Compound 3, half-life: > 1.5 h
Compound 3 ended at the assay's limit (the forecaster's own chance of this, stated with the estimate: 35%); the middle value lies beyond the limit too.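

In this assay compound 3 gives > 1.5 h, which is a limit of the assay and not a number. Compound 2 gives > 2.75 h, also a limit, and the steps from compound 1 and from compound 2 to compound 3 cannot be read. The compounds shown leave open how trifluoromethyl compares with ethyl or phenyl on this carbonyl carbon.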